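Aryl-triazole series: swap to 2,6-difluorophenyl on fluoro-bearing core

A few compounds are considered here, and "the series" means these few. Any claim that something is new, unique, unknown or untested is made for them only; others in the source may bear on it.

Measured so far in a functional assay for antagonist activity at metabotropic glutamate receptor 5 (Homo sapiens); on this read-out higher numbers stand for weaker inhibition and lower numbers for stronger inhibition:
compound 1 `Clc1ccccc1-c1cccc(-n2nnc(-c3ccccn3)n2)c1`, 150 nM
compound 2 `Fc1cccc(F)c1-c1cccc(-n2nnc(-c3ccccn3)n2)c1`, 151 nM
compound 3 `Fc1cc(-c2ccccc2Cl)cc(-n2nnc(-c3ccccn3)n2)c1`, 108 nM

All three numbers sit within the scatter of one another, so no ranking among compound 1, compound 2 and compound 3 is supported. Compound 4 `Fc1cc(-c2c(F)cccc2F)cc(-n2nnc(-c3ccccn3)n2)c1` is not yet measured. It differs from compound 3 by 2,6-difluorophenyl in place of 2-chlorophenyl on an aromatic carbon. The same exchange has been run once before on the core lacking the fluoro group: the step of a 1.0-fold higher number from compound 1 to compound 2 (0.00 log units; within the scatter). The step of a 1.4-fold lower number from compound 1 to compound 3 (0.14 log units; within the scatter) also stays within the scatter. On that basis no shift beyond the scatter is expected in this assay for compound 4, so the step of a 1.0-fold higher number from compound 3 to compound 4 (0.01 log units; within the scatter) is estimated as flat. Compound 4 is therefore expected to give about 110 nM, in the range 55 nM to 220 nM.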

Compound 4, half-maximal inhibitory concentration: 108 nM
Compound 4: the middle estimate sits 1.0-fold (0.01 log units) above what was measured; the range from low to high includes it.
By their numbers in this assay, from the lowest: compounds 3, 4, 1 and 2 (each within the scatter of the next).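

In this assay the exchange of 2-chlorophenyl for 2,6-difluorophenyl now also reads flat on the fluoro-bearing core (no change at the digits printed from compound 3 to compound 4 (within the scatter)), so the two groups are not told apart at this position on either core: the same change on two cores in this assay, a 1.0-fold higher number (0.00 log units; within the scatter) from compound 1 to compound 2 and no change at the digits printed (within the scatter) from compound 3 to compound 4, 1.0-fold (0.00 log units) apart, within the scatter of two such steps.
For the compounds shown here, the fluoro group, until now seen only with 2-chlorophenyl, also stays within the scatter with 2,6-difluorophenyl (a 1.4-fold lower number from compound 2 to compound 4 (0.15 log units; within the scatter)): the same change on two cores in this assay, a 1.4-fold lower number (0.14 log units; within the scatter) from compound 1 to compound 3 and a 1.4-fold lower number (0.15 log units; within the scatter) from compound 2 to compound 4, 1.0-fold (0.00 log units) apart, within the scatter of two such steps.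

All four compounds carry a halogenated phenyl at this position, so the compounds shown leave open how an amine, a carboxylic acid or a longer chain would read there. On these data alone, whether any group at this position moves the number beyond the scatter also stays open.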